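The source may hold more compounds than are shown below. What is called first, only, known or untested is meant among the compounds shown, and "the series" means these compounds.

Compound 1 `CCCCOc1ccc(-c2c(C)[nH]c(=O)n2C)cc1`: 5100 nM
Compound 2 `CCCCCc1ccc(-c2c(C)[nH]c(=O)n2C)cc1`: 5900 nM

In a functional assay on brain (Rattus norvegicus, strain Wistar) for inhibition (on this read-out higher numbers stand for weaker inhibition and lower numbers for stronger inhibition), compound 2 gives 5900 nM, level with compound 1 within the scatter. Compound 3 `Cc1[nH]c(=O)n(C)c1-c1ccc(-c2ccccc2)cc1` has phenyl in place of pentyl on an aromatic carbon. For the measured compounds named here, the only measured step, a 1.2-fold higher number from compound 1 to compound 2 (0.06 log units; within the scatter), is pentyl in place of butoxy and lies within the scatter. It swaps one open chain for another, so it bears only loosely on a change to a ring, and no step beyond the scatter is expected, though with wide uncertainty. The expected change is a 1.2-fold lower number from compound 2 to compound 3 (0.09 log units; within the scatter). For compound 3 the estimated value is 4800 nM, with an expected range of 1500 nM to 15000 nM.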

Compound 3, half-maximal inhibitory concentration: 6300 nM
Compound 3: middle estimate off by 1.3-fold (0.12 log units), on the low side; the range from low to high includes it.
By their numbers in this assay, from the lowest: compounds 1, 2 and 3 (each within the scatter of the next).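

In this assay, phenyl in place of pentyl gives a 1.1-fold higher number from compound 2 to compound 3 (0.03 log units; within the scatter) and phenyl in place of butoxy gives a 1.2-fold higher number from compound 1 to compound 3 (0.09 log units; within the scatter) on the same aromatic carbon. The earlier compounds shown here compared only two open chains, whereas these steps show that a six-membered aromatic ring at this position leaves compound 3 level with both. Nothing measured here accounts for this. Still open, from the compounds shown here alone, is whether an amine or a carboxylic acid at this position would shift the number, and whether a much shorter chain such as methyl would.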